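The compounds below may be only part of what the source reports. "The series", "measured", "known", "first", "only" and "open" are said of these compounds alone.

Measured compounds:
compound 1 `CC1(C)Oc2ccc(C#N)cc2[C@@H](/N=C(\NC#N)Sc2ccccc2)[C@@H]1O` — 4900 nM
compound 2 `CC1(C)Oc2ccc(C#N)cc2[C@@H](NC(=O)Nc2ccccn2)[C@@H]1O` — 440 nM

Both were tested in a functional assay (aorta) with Rattus norvegicus as the target; on this read-out lower numbers stand for stronger inhibition and higher numbers for weaker inhibition. Compound 1 gives 4900 nM, the highest of the two numbers and so the weaker inhibitor of the pair. Compound 2 gives 440 nM, and the gap between compound 2 and compound 1 lies beyond the usual scatter of repeated measurements.

Compound 3 `Cc1ccc(N/C(=N/[C@@H]2c3cc(C#N)ccc3OC(C)(C)[C@H]2O)NC#N)cc1C` has not yet been measured. It differs from compound 1 in one place: (3,4-dimethylphenyl)amino in place of phenylsulfanyl on a carbon with a double bond to nitrogen. Among the measured compounds shown here, no measured pair shows exactly this exchange, so any expectation rests on the two numbers at hand and on the change itself, in which a group with one hydrogen-bond donor replaces one with a single hydrogen-bond acceptor.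

The expected step from compound 1 to compound 3 is a 3.3-fold lower number from compound 1 to compound 3 (0.51 log units; beyond the scatter), a move toward a lower number and hence stronger inhibition. Compound 3 is estimated at 1500 nM, with a range from 300 nM to 7000 nM.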

Compound 3, half-maximal inhibitory concentration: 5100 nM
Compound 3: middle estimate off by 3.4-fold (0.53 log units), on the low side; low and high end bracket the measured number.
By their numbers in this assay, from the lowest: compound 2; then compounds 1 and 3 (each within the scatter of the next).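

In this assay, putting (3,4-dimethylphenyl)amino in place of phenylsulfanyl on a carbon with a double bond to nitrogen gives a 1.0-fold higher number from compound 1 to compound 3 (0.02 log units; within the scatter), so this read-out does not separate the two compounds. At this position, then, a group with a hydrogen-bond donor and two extra methyl groups on its ring can replace one with a hydrogen-bond acceptor without a change beyond the scatter. Nothing available explains why the number holds across this exchange.

The exchange alters the linking atom and the ring's methyl groups together, so the step cannot show what each contributes, or whether their contributions cancel. Plain phenylamino would separate those two parts, while an aliphatic amine such as cyclohexylamino would show whether this position needs an aromatic ring at all.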